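A few compounds are considered here, and "the series" means these few. Any claim that something is new, unique, unknown or untested is made for them only; others in the source may bear on it.

Compound 1 `CCCCCc1cc(-c2cn([C@H]3C[C@H](OC(C)=O)[C@@H](COC(C)=O)O3)c(=O)[nH]c2=O)on1` and compound 2 `CC(=O)OC[C@H]1O[C@@H](n2cc(-c3cc(-c4ccccc4)no3)c(=O)[nH]c2=O)C[C@@H]1OC(C)=O` share the same core and differ only in the group on the aromatic carbon of the five-membered ring. In an ADME assay on Vero cells (Chlorocebus sabaeus) for cytotoxicity (a lower number here means that less compound is tolerated, a higher number that more compound is tolerated), compound 1 gives 3000 nM, and compound 2 gives 3000 nM. Among the measured compounds shown here, the single measured step, no change at the digits printed from compound 1 to compound 2 (within the scatter), leaves compound 1 level with compound 2 in this assay; there is no order between the two.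

Compound 3 `CC(=O)OC[C@H]1O[C@@H](n2cc(-c3cc(-c4ccc(C(C)C)cc4)no3)c(=O)[nH]c2=O)C[C@@H]1OC(C)=O` is the next member to be examined. It differs from compound 1 as follows: 4-isopropylphenyl in place of pentyl on an aromatic carbon. For the measured compounds named here, the only step that bears on this change is the one from compound 1 to compound 2, in which phenyl in place of pentyl produced no change within the scatter. Going by the values given here, compound 3 carries 4-isopropylphenyl rather than phenyl at that position, and no measured pair shows what the added isopropyl on the ring contributes. On the evidence of the phenyl step alone, the expectation for this assay is a step of no change at the digits printed from compound 1 to compound 3 (within the scatter), that is, none beyond the scatter. Compound 3 is therefore expected to give about 3000 nM, with a range from 1200 nM to 7500 nM.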

Compound 3, half-maximal cytotoxic concentration: 3000 nM
Compound 3: the middle estimate sits on the measured number at the digits printed; the range from low to high includes it.
By their numbers in this assay, from the lowest: compounds 1, 2 and 3 (each within the scatter of the next).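

In this assay, among the compounds shown here, the added isopropyl on the phenyl group gives the first reading of a substituent on that group: no change at the digits printed from compound 2 to compound 3 (within the scatter) is the step for isopropyl in place of hydrogen. The larger 4-isopropylphenyl, with 9 heavy atoms against 5 for pentyl, gives no change at the digits printed from compound 1 to compound 3 (within the scatter) as its step, so a second aryl group at this aromatic carbon of the five-membered aromatic ring also stands level with the pentyl compound. Across compounds 1, 2 and 3, this position therefore tolerates an alkyl chain, an unsubstituted phenyl and an alkyl-substituted phenyl with no separation in this read-out, and no measurement available here offers an explanation for that flat result.

Going by these compounds, all three groups at this position are made of carbon only and have no hydrogen-bond donors or acceptors, so it remains open whether an amine or a carboxylic acid there would give a value outside the scatter. Also open is what the two acetyl groups on the shared core contribute, as they are present in every compound shown.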